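Swapping methyl for benzyl on the amine of compound 2

The compounds below may be only part of what the source reports. "The series", "measured", "known", "first", "only" and "open" are said of these compounds alone.

Compound 1, with structure `c1ccc(CNCC[C@@H]2CCO[C@H](c3ccccc3)O2)cc1`, carries a benzyl group on its amine and a single phenyl on the acetal carbon of the shared core. In an assay for displacement of a labelled ligand from Sigma non-opioid intracellular receptor 1 (Cavia porcellus), read by scintillation counting (on this read-out lower numbers stand for stronger inhibition and higher numbers for weaker inhibition), compound 1 gives 19 nM. Compound 2, with structure `CNCC[C@@H]1CCOC(c2ccccc2)(c2ccccc2)O1`, carries instead a methyl group on the amine and two phenyl groups on the acetal carbon. In this assay compound 2 reaches only a limit, > 10000 nM, so no number is known for it; it sits on the weak side of the two values shown, as the line the limit of > 10000 nM in this assay, at which 1 of the 2 values shown sits, records. Compound 3, with structure `c1ccc(CNCC[C@@H]2CCOC(c3ccccc3)(c3ccccc3)O2)cc1`, has not yet been measured in this assay. It differs from compound 2 in one place: phenyl in place of hydrogen on a saturated chain carbon bound to an amine nitrogen. Because compound 2 stands at a limit (the limit of > 10000 nM in this assay, at which 1 of the 2 values shown sits), the size of the step cannot be pinned down, and the estimate therefore spans a wide band. The expected step in this assay from compound 2 to compound 3 is an at least 20-fold lower number from compound 2 to compound 3 (1.30 log units; beyond the scatter), toward stronger binding. On that basis compound 3 is estimated at 500 nM, with a range from 40 nM to 8000 nM.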

Compound 3, inhibition constant: 320 nM
The estimate for compound 3 lay 1.6-fold (0.19 log units) above the measured number; measured number inside the range.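

In this assay, the group on the amine proves to matter a great deal on the core with two phenyl groups on the acetal carbon: changing methyl to benzyl gives an at least 31-fold lower number from compound 2 to compound 3 (1.49 log units; beyond the scatter). With benzyl on the amine, two phenyl groups on the acetal carbon still allow a real number, compound 3 giving 320 nM, while compound 1, with one phenyl there, gives 19 nM. Compound 2 stands only at a limit, so this step has a floor but no known ceiling: the limit of > 10000 nM in this assay, at which 1 of the 3 values shown sits.

As far as these compounds go, how much of the step belongs to benzyl alone stays open, since the effect of the same change from methyl to benzyl on the core with a single phenyl cannot be read from these compounds. Also open, from the compounds shown here alone, is whether the ring of the benzyl group is what counts, which a plain ethyl group on the amine could test, and whether a longer chain, such as phenethyl in place of benzyl, would move the number further in either direction.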